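The source may report more compounds than this note shows. Statements on the series, on what has been measured and on what is new or still open speak of the compounds shown alone.

Measured so far in an assay on isolated protein for inhibition of protein kinase C delta type (Homo sapiens), read by TR-FRET, with a stated time of 2 h; on this read-out lower numbers stand for stronger inhibition and higher numbers for weaker inhibition:

compound 1 `N#Cc1cnc(NCc2cnccc2C(F)(F)F)cc1NC[C@H]1CC[C@@H](O)CC1`: 500 nM
compound 2 `N#Cc1cnc(NCc2ccccc2)cc1N[C@H]1CC[C@@H](O)CC1`: > 10000 nM
compound 3 `CC1(C)[C@@H](O)C[C@H]1Nc1nc(NCc2cnccc2C(F)(F)F)ncc1C#N`: 600 nM

Among the two plain numbers, compound 1 holds the lower one, and compound 3 stands close to it, within the scatter of repeated measurements, so no order between them can be read. Compound 2 returned no number in this assay but only a limit, (the limit of > 10000 nM in this assay, at which 1 of the 3 values shown sits).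

Compound 4 `CC1(C)[C@@H](Nc2cc(NCc3cnccc3C(F)(F)F)ncc2C#N)C[C@H]1C(N)=O` has not yet been measured. It differs from compound 1 in one place:

3-carbamoyl-2,2-dimethylcyclobutyl in place of (4-hydroxycyclohexyl)methyl on a nitrogen on an aromatic ring

Among the compounds with values here, no measured pair differs by exactly this change, so the size of the step can only be expected. Compound 3, which also carries a 2,2-dimethylcyclobutyl on its ring nitrogen, gives 600 nM, and compound 1 gives 500 nM, which suggests the change from the cyclohexyl-methyl group to the cyclobutyl group does not move the number far. For compound 4 the step from compound 1 is therefore expected to be small, a 1.6-fold higher number from compound 1 to compound 4 (0.20 log units; within the scatter), possibly none beyond the scatter. Compound 4 is expected to give about 800 nM in this assay, estimated between 250 nM and 3000 nM.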

Compound 4, half-maximal inhibitory concentration: 4500 nM
Compound 4: the middle estimate sits 5.6-fold (0.75 log units) below what was measured; measured number outside the range, above it.
By their numbers in this assay, from the lowest: compounds 1 and 3 (each within the scatter of the next); then compound 4. At a limit, above all of these: compound 2.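

In this assay, within the data shown here, the first step that can be read at this position is a 9.0-fold higher number from compound 1 to compound 4 (0.95 log units; beyond the scatter), so the group on a nitrogen on an aromatic ring is not indifferent: replacing (4-hydroxycyclohexyl)methyl with 3-carbamoyl-2,2-dimethylcyclobutyl weakens inhibition beyond the scatter. The two groups have the same counted hydrogen-bond donors and acceptors and no net charge, so those counts alone do not keep the number in place, while the change swaps a six-membered ring for a four-membered ring and a hydroxyl for a carbamoyl in a single step. Nothing shown here gives a measured reason for this step.

The change alters the ring, the link to the nitrogen and the end group together, so the compounds shown cannot say which of these parts accounts for the step. As far as these compounds go, it also remains open how the same position would read with an amine or a carboxylic acid in place of the carbamoyl on the 2,2-dimethylcyclobutyl ring, or with a hydroxyl there on the core of compound 4.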